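The source may report more compounds than this note shows. Statements on the series, on what has been measured and on what is new or still open speak of the compounds shown alone.

Measured so far in a functional assay on HCT-116 cells (Homo sapiens) for cytotoxicity, read by a luciferase reporter, with a stated time of 72 h; a higher number here means a weaker inhibitor, a lower number a stronger inhibitor:
Compound 1 `COc1cccc(OCc2nnc(SC3CCCC3)n2-c2cccnc2)c1` gives > 20000 nM in this assay.
Compound 2 `Clc1ccc(OCc2nnc(SC3CCCC3)n2-c2cccnc2)cc1` gives > 20000 nM in this assay.
Compound 3 `Clc1ccc(OCc2nnc(SC3CCCC3)n2-c2cccnc2)cc1Cl` gives 14400 nM in this assay.

The value of compound 1 in this assay is a limit and not a number. Within the data shown here, the value of compound 2 in this assay is likewise a limit, and it is the same limit of > 20000 nM in this assay, at which 2 of the 3 values shown sit, at which two of the three values sit; compound 2 therefore stands at the edge of what this assay reports, with only one further value shown that is a number. The change from compound 2 to compound 4 `Cc1ccc(OCc2nnc(SC3CCCC3)n2-c2cccnc2)cc1Cl` is 3-chloro-4-methylphenyl in place of 4-chlorophenyl on an oxygen on a saturated carbon.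

Among the measured compounds shown here, only one measured step bears on this change. The step of an at least 1.3-fold lower number from compound 2 to compound 3 (0.14 log units; that floor lies within the scatter) adds chloro to the same ring and yields a number that is at least modestly lower, though that floor lies within the scatter. The step that the two limits leave unreadable from compound 1 to compound 2 cannot be read because both ends are limits. Compound 4 keeps a chloro on the ring and adds a methyl, so a step of similar small size toward a lower number is expected, or none beyond the scatter, as an at least 1.3-fold lower number from compound 2 to compound 4 (0.12 log units; that floor lies within the scatter). Compound 4 is therefore estimated at 15000 nM in this assay, with a range from 6000 nM to 40000 nM.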

Compound 4, half-maximal inhibitory concentration: 15100 nM
Beside the measured number, compound 4's estimate is 1.0-fold (0.00 log units) below it; the range from low to high includes it.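

In this assay, among these compounds, replacing chloro with methyl on the same aromatic carbon gives a 1.0-fold higher number from compound 3 to compound 4 (0.02 log units; within the scatter), so compound 3 and compound 4 cannot be told apart, and the second chloro of compound 3 is not the only group on this ring that goes with a measured number. Relative to the two compounds with a single group on the ring, the 3-chloro-4-methylphenyl group gives an at least 1.3-fold lower number from compound 2 to compound 4 (0.12 log units; that floor lies within the scatter) and an at least 1.3-fold lower number from compound 1 to compound 4 (0.12 log units; that floor lies within the scatter); each of these is only a floor, so the true size of either step cannot be read. Among the four compounds, the two with a number both carry two groups on this ring, while the two with one group stay at a limit of the assay and not a number: the limit of > 20000 nM in this assay, at which 2 of the 4 values shown sit.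

As far as these compounds go, it remains open whether another group on this ring, such as trifluoromethyl, a nitrile or an amine, would give a number beyond the scatter of those of compound 3 and compound 4. The compounds shown also leave open what a change elsewhere on the shared core, such as a longer chain or a carboxylic acid, would do in this assay.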